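From chloro to methoxy at the top of the scale

The source may hold more compounds than are shown below. What is called first, only, known or untested is meant among the compounds shown, and "the series" means these compounds.

In an ADME assay on HuDe cells (Homo sapiens) for cytotoxicity, read by MTT assay, with a stated time of 72 h (a lower number here means a stronger inhibitor, a higher number a weaker inhibitor), compound 1 (`NC(=O)c1cc(Cl)ccc1NC(=O)COc1ccccc1`) gives 808000 nM as the highest of three numbers. Compound 2 (`Cc1ccccc1OCC(=O)Nc1ccc(Cl)cc1C(N)=O`) stands at 27300 nM and compound 3 (`NC(=O)c1cc(I)ccc1NC(=O)COc1ccc(Cl)cc1Cl`) at 33800 nM on that scale. Compound 4 (`COc1ccc(NC(=O)COc2ccccc2)c(C(N)=O)c1`) is still unmeasured and has methoxy in place of chloro on an aromatic carbon. Going by the values given here, only one measured step exists, namely a 30-fold lower number from compound 1 to compound 2 (1.47 log units; beyond the scatter) for methyl in place of hydrogen on an aromatic carbon, and it bears only loosely on a change at the chloro. With compound 1 at 808000 nM far above both others, a smaller drop in this assay is expected, and the estimated step is a 2.7-fold lower number from compound 1 to compound 4 (0.43 log units; beyond the scatter) for this swap. For compound 4 the expected value is 300000 nM with a range of 60000 nM to 1200000 nM as estimated.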

Compound 4, half-maximal inhibitory concentration: 942000 nM
Compound 4: middle estimate off by 3.1-fold (0.50 log units), on the low side, within the range that was stated.
By their numbers in this assay, from the lowest: compounds 2 and 3 (each within the scatter of the next); then compounds 1 and 4 (each within the scatter of the next).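

In this assay, methoxy in place of chloro, on the aromatic carbon meta to a carbamoyl group and para to a large group, gives a 1.2-fold higher number from compound 1 to compound 4 (0.07 log units; within the scatter), so the two compounds cannot be told apart. At this position, then, the two groups read alike despite their different heavy-atom counts and the hydrogen-bond acceptor that methoxy adds. Nothing available explains this result. As far as these compounds go, whether an amine, a carboxylic acid or a longer chain such as butoxy on this carbon would also read alike remains open.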